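The source may report more compounds than this note shows. Statements on the series, on what has been measured and on what is new or still open speak of the compounds shown alone.

Measured so far:
compound 1 `c1ccc(-c2cn3ccnc3c(-c3ccc4ncn(C5CCCCC5)c4c3)n2)cc1`: 28.8%
compound 2 `c1ccc2c(-c3cn4ccnc4c(-c4ccc5ncn(C6CCCCC6)c5c4)n3)cccc2c1`: 11.7%

In a functional assay on SN12C cells (Homo sapiens) for inhibition, read by sulforhodamine B assay, with a stated time of 48 h, tested at 10 uM (a lower number here means less inhibition, a higher number more inhibition at the concentration tested (going by the name of the read-out)), compound 2 gives 11.7%, the lowest of the two numbers; the nearest is compound 1, which gives 28.8%. For the measured compounds named here, the single measured step, a number 17.1 percentage points lower from compound 1 to compound 2 (beyond the scatter), is a modest fall beyond the scatter.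

Compound 3 `CC(=O)c1ccc(-c2cn3ccnc3c(-c3ccc4ncn(C5CCCCC5)c4c3)n2)cc1` differs from compound 2 as 4-acetylphenyl in place of naphthalen-1-yl on an aromatic carbon. Going by the values given here, this change undoes the naphthalen-1-yl-for-phenyl step and at the same time brings in the acetyl group; for that second part no measured step exists, so its contribution is unknown. Among the compounds with values here, since the one step that bears on it, a number 17.1 percentage points lower from compound 1 to compound 2 (beyond the scatter), is reversed here, the expected direction is back toward the level of compound 1. The expected step is a number 14.3 percentage points higher from compound 2 to compound 3 (beyond the scatter), a rise beyond the scatter. Compound 3 is therefore estimated at 26%, within a range of 8% to 45%.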

Compound 3, a percentage reported as inhibition, at one concentration (the size of the read-out at that concentration, not a potency): 6.33%
The estimate for compound 3 lay 19.7 percentage points above the measured number, outside the stated range (below it).
By their numbers in this assay, from the lowest: compounds 3 and 2 (each within the scatter of the next); then compound 1.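

In this assay, the 4-acetylphenyl group of compound 3 compared with the plain phenyl gives a number 22.5 percentage points lower from compound 1 to compound 3 (beyond the scatter), so adding this single acetyl on the ring is not neutral at this position. Against naphthalen-1-yl, the same group gives a number 5.4 percentage points lower from compound 2 to compound 3 (within the scatter), so a group with two carbon rings and a group with one carbon ring plus a hydrogen-bond acceptor stand level here. Among these three compounds, both departures from plain phenyl go with lower numbers, and none goes against this.

As far as these compounds go, whether a small fluorine or methoxy on the phenyl, or an amine in place of the acetyl, would hold the level of compound 1 stays open, as does whether the carbonyl itself matters compared with a plain ethyl. Nothing on hand accounts for these steps.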